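The source may report more compounds than this note shows. Statements on the series, on what has been measured and on what is new or still open speak of the compounds shown alone.

Measured compounds:
compound 1 `CC(CC(=O)/N=C(\N)NCCCc1ccccc1)c1ccccc1` with 5.89;
compound 2 `N/C(=N\C(=O)CC(c1ccccc1)c1ccccc1)NCCCc1ccccn1` with 5.68.

Both numbers come from a functional assay on Sf9 cells for antagonist activity at histamine H2 receptor (Homo sapiens), with stated times of 2 min and 20 min; on this read-out lower numbers stand for lower potency and higher numbers for higher potency (the scale is a negative logarithm). In this assay compound 1 gives 5.89, and in this assay compound 2 gives 5.68; the two values lie within the scatter of each other, so neither compound can be set above the other on this read-out.

Compound 3 `N/C(=N\C(=O)CC(c1ccccc1)c1ccccc1)NCCCc1cccnc1` differs from compound 2 in one place: pyridin-3-yl in place of pyridin-2-yl on a saturated chain carbon, three bonds along the chain from an amine nitrogen. Among the measured compounds shown here, no step between measured compounds tells how this change acts in this assay, so the expectation rests on compound 2 alone. The account holds that the step from compound 2 to compound 3 should stay small, with a number 0.12 log units higher from compound 2 to compound 3 (within the scatter) expected to fall within the scatter, in no clear direction. Compound 3 is therefore estimated at 5.8, with a range from 5.3 to 6.4 in this assay.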

Compound 3, negative logarithm of the antagonist equilibrium constant: 6.14
Beside the measured number, compound 3's estimate is 0.34 log units below it; the measured number falls inside the stated range.
By their numbers in this assay, from the lowest: compounds 2, 1 and 3 (each within the scatter of the next, the first and the last beyond it).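

In this assay, pyridin-3-yl in place of pyridin-2-yl on a saturated chain carbon, three bonds along the chain from an amine nitrogen, gives a number 0.46 log units higher from compound 2 to compound 3 (beyond the scatter). Among the compounds shown here, this is the first step read at this place, and it shows that the read-out can separate two groups with the same counts of heavy atoms and hydrogen-bond acceptors, so those counts alone do not fix the number here. Nothing measured among these compounds accounts for the step.

The compounds shown leave open how pyridin-4-yl or imidazol-4-yl would read at this same place, and whether a longer chain would keep the step. They also leave open whether the same change would give a step of like size on the core of compound 1.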